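A Methyl Step on the Amine Chain

A few compounds are considered here, and "the series" means these few. Any claim that something is new, unique, unknown or untested is made for them only; others in the source may bear on it.

Compound 1 `CCCCCCCCCNC[C@@H]1OC[C@H](N)[C@H]1O`: 60300 nM
Compound 2 `CCCCCCCNC[C@@H]1OC[C@H](N)[C@H]1O`: > 128000 nM

Both compounds were tested in a functional assay on MCF7 cells (Homo sapiens) for antiproliferative activity, read by MTT assay, with a stated time of 72 h; on this read-out higher numbers stand for weaker inhibition and lower numbers for stronger inhibition. Compound 1 gives a measured number there. Compound 2 stands at > 128000 nM, which is a limit of the assay and not a number.

Compound 3 `CCCCCCCCNC[C@@H]1OC[C@H](N)[C@H]1O` differs from compound 2 by methyl in place of hydrogen on a saturated chain carbon, seven bonds along the chain from an amine nitrogen. Going by the values given here, one measured step bears on this change. It is an at least 2.1-fold higher number from compound 1 to compound 2 (0.32 log units; beyond the scatter), with hydrogen in place of ethyl on a carbon described in the same words. Compound 3 reverses part of that change, so a modest move toward a lower number in this assay is expected, and it may stay within the scatter. The expected step is an at least 1.2-fold lower number from compound 2 to compound 3 (0.10 log units; that floor lies within the scatter). Compound 3 is estimated at 100000 nM, within an expected range of 55000 nM to 170000 nM.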

Compound 3, half-maximal inhibitory concentration: > 128000 nM
Compound 3: no number, only a limit; the forecaster's own chance of this, stated with the estimate: 40%; middle value at least 1.2-fold (0.10 log units) away from the limit.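

In this assay, compound 3 gives > 128000 nM, which is a limit of the assay and not a number. The added methyl therefore did not bring the chain to a measured value, and a single further carbon now separates a measured number from the limit: hydrogen in place of methyl on a saturated chain carbon, eight bonds along the chain from an amine nitrogen, gives an at least 2.1-fold higher number from compound 1 to compound 3 (0.32 log units; beyond the scatter). The step between compound 2 and compound 3 cannot be read, as both values are limits: the limit of > 128000 nM in this assay, at which 2 of the 3 values shown sit.

From the compounds shown here alone, how far compound 2 and compound 3 lie past that limit remains open. Also open, going by these compounds, is whether a longer chain than that of compound 1 would give a lower number in this assay.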